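Removing a Methoxy Group from an Inactive Compound

This account rests on a few compounds, and the source may have more. Where it says the series, first, only, none or still open, it means among the compounds named here.

Compound 2 `COc1ccc(CNC(=O)/C=C/c2coc3cc(O)ccc3c2=O)cc1` is one of two compounds examined in a functional assay on L02 cells (Homo sapiens) for inhibition, read by MTT assay, with a stated time of 48 h; on this read-out lower numbers stand for stronger inhibition and higher numbers for weaker inhibition. In this assay compound 2 gives only the limit of > 200000 nM, so no number is known for it, only that it lies beyond what the measurement can report. Compound 1 `COc1ccc2c(=O)c(/C=C/C(=O)Nc3cccc(C)c3)coc2c1` behaves the same way: in this assay compound 1 is reported as > 200000 nM, again a limit rather than a number. Both results sit at the limit of > 200000 nM in this assay, at which 2 of the 2 values shown sit, so neither compound shows measurable inhibition of these cells. Compound 3 `O=C(/C=C/c1coc2cc(O)ccc2c1=O)NCc1ccccc1` has not yet been measured. It differs from compound 2 in one place: hydrogen in place of methoxy on an aromatic carbon. Because compound 2 sits at the limit > 200000 nM, a change in this assay from compound 2 to compound 3 cannot be counted in either direction; none beyond the usual scatter is expected, and the most likely outcome is once more a limit. Compound 3 is therefore expected to give about 300000 nM, within a range from 150000 nM to 1000000 nM, which corresponds to an expected step that the limit leaves unreadable from compound 2 to compound 3.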

Compound 3, half-maximal inhibitory concentration: > 200000 nM
Compound 3 was reported as a limit; the forecaster's own chance of this, stated with the estimate: 85%; the middle value does not contradict the limit.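

Compound 2 and compound 3 both end at a limit rather than a number in this assay, so no step can be read for the change from 4-methoxyphenyl to phenyl: the limit of > 200000 nM in this assay, at which 3 of the 3 values shown sit. The compounds shown leave open how far past that limit each one lies, and so whether the methoxy group affects inhibition at all.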